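Series notes: methoxy added to compound 3

The source may report more compounds than this note shows. Statements on the series, on what has been measured and on what is new or still open speak of the compounds shown alone.

In a functional assay on DU-145 cells (Homo sapiens) for cytotoxicity, read by MTT assay (a lower number here means a stronger inhibitor, a higher number a weaker inhibitor), compound 1 `COc1ccc(/C=C/C(=O)c2ccc(OCC3CO3)cc2)cc1` gives 43300 nM and compound 2 `COc1ccc(C(=O)/C=C/c2ccc(OCC3CO3)cc2)cc1` gives 36900 nM, two values within the scatter of each other. Compound 3 `O=C(/C=C/c1ccc(OCC2CO2)cc1)c1ccc(OCC2CO2)cc1` gives > 50000 nM, which is a limit of the assay and not a number. Compound 4 `COc1cc(OCC2CO2)ccc1/C=C/C(=O)c1ccc(OCC2CO2)cc1` differs from it by methoxy in place of hydrogen on an aromatic carbon. Among the measured compounds shown here, two measured steps bear on this only indirectly, since each concerns a different change: an at least 1.1-fold higher number from compound 1 to compound 3 (0.06 log units; that floor lies within the scatter) and an at least 1.3-fold higher number from compound 2 to compound 3 (0.13 log units; that floor lies within the scatter), and both floors lie within the scatter. No step beyond the scatter is therefore expected in this assay. The estimated change is an at least 1.1-fold lower number from compound 3 to compound 4 (0.04 log units; that floor lies within the scatter). Compound 4 is expected at 45000 nM, within an estimated range of 20000 nM to 90000 nM.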

Compound 4, half-maximal inhibitory concentration: > 50000 nM
Compound 4: a limit, no number (the forecaster's own chance of this, stated with the estimate: 55%); middle value at least 1.1-fold (0.04 log units) from the limit.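

Compound 3 and compound 4 both give a limit and not a number in this assay, so no step can be read between them: the limit of > 50000 nM in this assay, at which 2 of the 4 values shown sit. As far as these compounds go, whether methoxy in place of hydrogen on an aromatic carbon changes the number in this assay stays open.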